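The source may report more compounds than this note shows. Statements on the series, on what has been measured and on what is new or still open speak of the compounds shown alone.

Compounds with numbers in hand:

Compound 1 `Clc1ccc(-c2noc(Cn3ccnc3)n2)cc1` gives > 500 mg/kg in a toxicity assay on the whole organism (strain Wistar) with Rattus norvegicus as the target, with a stated time of 1 h (on this read-out lower numbers stand for an effect already at smaller amounts and higher numbers for an effect only at larger amounts of compound), which is a limit of the assay and not a number.
Compound 2 `Cc1ccc(-c2noc(Cn3cncn3)n2)cc1` gives 171 mg/kg in this assay.
Compound 3 `Cc1cccc(-c2noc(Cn3cncn3)n2)c1` gives 219 mg/kg in this assay.

Compound 2 stands at the lower of the two numbers, with compound 3 within the scatter of it; the remaining value is a limit (the limit of > 500 mg/kg in this assay, at which 1 of the 3 values shown sits). Compound 4 `Clc1ccc(-c2noc(Cn3cncn3)n2)cc1` is not yet measured. It differs from compound 2 by chloro in place of methyl on an aromatic carbon. Going by the values given here, no pair of measured compounds shares this change, so there is no measured step to lean on. The expected step in this assay from compound 2 to compound 4 is a 1.3-fold higher number from compound 2 to compound 4 (0.13 log units; within the scatter), not clearly beyond the scatter in either direction. Compound 4 is therefore estimated at 230 mg/kg, within 110 mg/kg to 550 mg/kg.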

Compound 4, dose for half-maximal effect: < 100 mg/kg
Compound 4 ended at the assay's limit; the forecaster's own chance of this, stated with the estimate: 25%; middle value at least 2.3-fold (0.36 log units) from the limit.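

In this assay, chloro in place of methyl on an aromatic carbon, para to a large group, gives an at least 1.7-fold lower number from compound 2 to compound 4 (0.23 log units; that floor lies within the scatter), so the printed floor of this step does not clear the scatter. Going by these compounds alone, the value of compound 4 is a limit and not a number: the limit of < 100 mg/kg in this assay, at which 1 of the 4 values shown sits. Changing the azole gives an at least 5.0-fold lower number from compound 1 to compound 4 (0.69 log units; beyond the scatter), the only step here printed as beyond the scatter, and its true size stays unknown with a limit at each end.

From the compounds shown here alone, how a methoxy group or an amine on that aromatic carbon would read in this assay remains open.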